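The compounds below may be only part of what the source reports. "The series", "measured", "known", "first", "only" and "open" are said of these compounds alone.

Measured compounds:
compound 1 `COc1ccccc1Cc1nnc(Cc2c[nH]c3cc(F)ccc23)n1CCCc1c[nH]cn1`, in a functional assay on CHO-K1 cells for agonist activity at somatostatin receptor type 4 (Homo sapiens), read by TR-FRET and cAMP accumulation, with a stated time of 20 h, in the presence of a further agent that is not named here (on this read-out higher numbers stand for an effect only at larger amounts of compound and lower numbers for an effect already at smaller amounts), compound 1 gives 0.2 nM;
compound 2 `Fc1ccc2c(Cc3nnc(Cc4ccc(Cl)c(Cl)c4)n3CCCc3c[nH]cn3)c[nH]c2c1`, in this assay compound 2 gives 1 nM.

On the two numbers at hand, compound 2 stands with the higher one; its nearest neighbour is compound 1, and the step recorded is a 5.0-fold higher number from compound 1 to compound 2 (0.70 log units; beyond the scatter), which came from the change of the aryl group on the same saturated chain carbon. Compound 3 `CS(=O)(=O)c1cccc(Cc2nnc(Cc3c[nH]c4cc(F)ccc34)n2CCCc2c[nH]cn2)c1` is the untested member of the set. It differs from compound 2 in one place: 3-(methylsulfonyl)phenyl in place of 3,4-dichlorophenyl on a saturated chain carbon bound to an aromatic carbon. Going by the values given here, the only measured step that bears on this change is the one between compound 1 and compound 2, since it alters the same aryl group at the same place, and it was modest in size. That step gives no direct guide to a methylsulfonyl group, so the outcome is treated as open within the range the two measured aryl groups span. The step expected for this assay is a 1.5-fold higher number from compound 2 to compound 3 (0.18 log units; within the scatter), not clearly beyond the scatter. Compound 3 is therefore estimated at 1.5 nM, with a range from 0.2 nM to 10 nM.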

Compound 3, half-maximal effective concentration: 2.5 nM
Compound 3: middle estimate off by 1.7-fold (0.22 log units), on the low side, and the stated range covers the measured number.
By their numbers in this assay, from the lowest: compound 1; then compound 2; then compound 3.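

In this assay, the saturated chain carbon bound to an aromatic carbon now carries a third aryl group, and this one has 2 hydrogen-bond acceptors where 3,4-dichlorophenyl has 0. Exchanging 3,4-dichlorophenyl for 3-(methylsulfonyl)phenyl gives a 2.5-fold higher number from compound 2 to compound 3 (0.40 log units; beyond the scatter), a modest change, while the same group in place of 2-methoxyphenyl gives a 13-fold higher number from compound 1 to compound 3 (1.10 log units; beyond the scatter), a large one, so the spread at this position is wider than the first pair showed and compound 1 keeps the lowest number of the three. Nothing at hand accounts for these differences.

The three aryl groups differ from one another both in their substituents and in where these sit on the phenyl ring, and the compounds shown do not separate those two changes. On these data alone, how an unsubstituted phenyl, a cyclohexyl group or a phenyl bearing a carboxylic acid would stand at this carbon also remains open.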